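The source may report more compounds than this note shows. Statements on the series, on what has been measured and on what is new or still open speak of the compounds shown alone.

Measured so far:
- compound 1 `Cc1ccc(-c2c(S(=O)(=O)c3ccccc3)cnc3cc(C)nn23)cc1`: 25.2%
- compound 2 `O=S(=O)(c1ccccc1)c1cnc2ncnn2c1-c1ccc(Br)cc1`: 4.2%
- compound 3 `Cc1cc2ncc(S(=O)(=O)c3ccccc3)c(-c3ccc(Br)cc3)n2n1`: 5.2%

In a functional assay on the whole organism for inhibition, with Mus musculus as the target, with a stated time of 2 h, at a dose of 50 mg/kg by the oral route (a lower number here means less inhibition, a higher number more inhibition at the dose given (going by the name of the read-out)), compound 1 stands highest of the three numbers. The nearest is compound 3, reached by a number 20 percentage points lower from compound 1 to compound 3 (beyond the scatter), a change of bromo in place of methyl on an aromatic carbon of the pendant ring. Compound 2 lies furthest; its value and that of compound 1 differ by more than the scatter, but the two structures differ in more than one place, so only the two values themselves are known for that pair.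

Compound 4 `Cc1ccc(-c2c(S(=O)(=O)c3ccccc3)cnc3cc(-c4ccccc4)nn23)cc1` is the next member. It differs from compound 1 by phenyl in place of methyl on an aromatic carbon. Among the compounds with values here, no measured step touches this position of the shared core: the one step known, bromo in place of methyl, sits on the pendant aromatic ring, not on the five-membered ring, so it gives no direction for the present change. Within the data shown here, the size of that step shows only that a single substituent swap can move the read-out beyond the scatter.

With nothing bearing directly on the change, compound 4 is expected to stay close to compound 1, so a number 3.2 percentage points lower from compound 1 to compound 4 (within the scatter) is estimated as a step within the scatter, with a wide range to either side. The expected value for compound 4 is 22%, with a range from 5% to 42%.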

Compound 4, a percentage reported as inhibition, in the whole organism at one dose (the size of the read-out at that dose, not a potency): 41%
Compound 4: the middle estimate sits 19 percentage points below what was measured, and the stated range covers the measured number.
By their numbers in this assay, from the lowest: compounds 2 and 3 (each within the scatter of the next); then compound 1; then compound 4.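

Phenyl can stand in place of methyl on this aromatic carbon of the five-membered ring without loss in this assay, and the number rises: a number 15.8 percentage points higher from compound 1 to compound 4 (beyond the scatter). Within the data shown here, this is the first step measured at this position, and its direction is opposite to that of the only earlier step, on the pendant ring, a number 20 percentage points lower from compound 1 to compound 3 (beyond the scatter), so in these compounds the two places do not move the read-out the same way. Nothing measured here accounts for the rise, and it rests on a single pair of compounds.

Still open, going by these compounds, is whether the rise requires an aromatic ring on this carbon, or whether a longer alkyl chain, an amine or a carboxylic acid in the same place would also give it. Also open is whether phenyl here keeps its step when bromo replaces methyl on the pendant ring, since the combination of the two changes is not among the compounds shown.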